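The source may report more compounds than this note shows. Statements on the series, on what has been measured and on what is new or still open speak of the compounds shown alone.

Measured so far in a physicochemical assay for lipophilicity; a lower number here means a more polar compound, a higher number a more lipophilic compound:
- compound 1 `Nc1nc(N)nc(-c2ccccc2[N+](=O)[O-])n1` gives 0.49
- compound 2 `C=CCN(CC=C)c1c(C)n(-c2ccccc2)c(=O)n(C)c1=O` gives 2.59

Within the data shown here, compound 2 holds the higher of the two numbers in this assay; the only other compound, compound 1, stands a good way lower, and that gap is beyond the usual scatter of the measurement. Among the measured compounds shown here, no pair of compounds that differ in a single place has been measured yet, so there is no single-step change to lean on.

The next compound, compound 3 `Cc1c(N(C)C)c(=O)n(C)c(=O)n1-c1ccccc1`, has not been measured in this assay. It differs from compound 2 in one place: dimethylamino in place of diallylamino on an aromatic carbon. The shared core and the phenyl group stay as they are.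

With a smaller group entering in place of a larger one, the value of compound 3 in this assay is expected to fall below that of compound 2, and the step from compound 2 to compound 3 is estimated at a number 1.74 log units lower from compound 2 to compound 3 (beyond the scatter), well beyond the scatter. Compound 3 is therefore expected to come out at 0.85, with a likely range from 0.35 to 1.35.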

Compound 3, partition coefficient: 1.19
Compound 3: middle estimate off by 0.34 log units, on the low side; measured number inside the range.
By their numbers in this assay, from the lowest: compound 1; then compound 3; then compound 2.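

Among these compounds, this is the first change in a single place in the set. In this assay, dimethylamino in place of diallylamino on this aromatic carbon gives a number 1.40 log units lower from compound 2 to compound 3 (beyond the scatter) while the shared core and the phenyl group stay as they are, so the number at this position clearly responds to what is carried on the amine nitrogen. The change takes the group from 7 heavy atoms to 3 and removes 2 double bonds, while the counts of hydrogen-bond donors and acceptors stay the same and neither group has a net charge; no measurement shown accounts for the size of the step.

As far as these compounds go, what remains open is how much of the step goes with the shorter chains and how much with the loss of the double bonds, since both change together between these two compounds. A dipropylamino group at the same position would pull those two changes apart, and a diethylamino group would show whether the number moves evenly between the two groups already measured or unevenly.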